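Replacing the Oxygen-Bridged Bicycle on the Amide of Compound 1

A few compounds are considered here, and "the series" means these few. Any claim that something is new, unique, unknown or untested is made for them only; others in the source may bear on it.

In an ADME assay on the whole organism (Rattus norvegicus, strain Wistar Han) for metabolic stability, read by LC-MS, with a stated time of 7 h (on this read-out higher numbers stand for a longer-lived compound and lower numbers for a shorter-lived compound), three compounds have been measured so far. Compound 1 `CNC(=O)c1cc(C(=O)N[C@H]2[C@@H]3COC[C@@H]32)c([C@@H](C)c2ccccc2)o1` gives 0.7 h, the lowest of the three numbers. Compound 3 `CNC(=O)c1cc(C(=O)N[C@H]2CC[C@H](OC)CC2)n([C@@H](C)c2ccccc2)n1` gives 1 h, a result that sits within the scatter of the figure for compound 1, so the two cannot be placed in order. Compound 2 `CNC(=O)c1cc(C(=O)N[C@H]2[C@@H]3C[C@@H](O)C[C@@H]32)n([C@@H](C)c2cccc(Cl)c2)n1` gives 2.9 h, which lies beyond the scatter above compound 1.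

The step under consideration leads from compound 1 to compound 4 `CNC(=O)c1cc(C(=O)N[C@H]2[C@@H]3C[C@@H](O)C[C@@H]32)c([C@@H](C)c2ccccc2)o1`, which has not yet been measured in this assay. The change is a group of 7 heavy atoms (6 carbon, 1 oxygen; one three-membered non-aromatic ring of carbon only, one five-membered non-aromatic ring of carbon only) in place of a group of 6 heavy atoms (5 carbon, 1 oxygen; one three-membered non-aromatic ring of carbon only, one five-membered non-aromatic ring with 1 hetero atom), on an amide-type nitrogen. The group that enters carries one hydrogen-bond donor where the leaving group carried none, and it brings one more defined stereocentre.

Within the data shown here, no step between two measured compounds isolates this exchange, so the direction rests on the spread of the numbers at hand. Compound 4 is expected to show a step of a 1.9-fold higher number from compound 1 to compound 4 (0.27 log units; within the scatter), a modest rise in half-life that need not clear the scatter. The estimate for compound 4 in this assay is 1.3 h, with a range from 0.6 h to 2.8 h.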

Compound 4, half-life: 1.2 h
Beside the measured number, compound 4's estimate is 1.1-fold (0.03 log units) above it, and the stated range covers the measured number.
By their numbers in this assay, from the lowest: compounds 1, 3 and 4 (each within the scatter of the next); then compound 2.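

Set against the core of compound 1, the exchange on the amide-type nitrogen gives a 1.7-fold higher number from compound 1 to compound 4 (0.23 log units; within the scatter) in this assay, the first step that isolates a change at this position. The group that enters carries a hydrogen-bond donor where the leaving group carried none, has a five-membered ring of carbon only in place of one with a hetero atom, and brings one more defined stereocentre, yet these differences together do not set compound 4 apart from compound 1 on this read-out. The compounds shown offer no measurement that could explain this result.

Compound 2 carries the same group on the amide but differs from compound 4 in more than one place, so the shown compounds cannot tell how much, if any, of the number for compound 2 belongs to this group. Also open, as far as these compounds go, is how the half-life would respond if an amine, a carboxylic acid or a methoxy group took the place of the hydroxyl on the five-membered carbon ring, or if the hydroxyl stood with the opposite stereochemistry.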